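The source may report more compounds than this note shows. Statements on the series, on what has been measured and on what is new or still open speak of the compounds shown alone.

Three compounds have been measured in an assay on isolated protein for inhibition of phosphatidylinositol 4,5-bisphosphate 3-kinase catalytic subunit beta isoform (Homo sapiens); a higher number here means a weaker inhibitor, a lower number a stronger inhibitor:

Compound 1, `COc1ccc(-c2ccnc(Nc3ccc(Cl)cc3Cl)n2)cc1`: 839 nM
Compound 2, `O=[N+]([O-])c1ccc(Nc2nccc(-c3ccc(F)cc3)n2)cc1`: 863 nM
Compound 3, `CC(C)c1ccccc1Nc1nccc(-c2ccc(Br)cc2)n1`: 874 nM

All three values fall within the usual scatter of one another, so compound 2 stands level with compound 1 and compound 3 rather than apart from either; nothing in these numbers sets any of the three ahead of or behind the others.

Compound 4, `O=[N+]([O-])c1ccc(Nc2nccc(-c3ccc(Br)cc3)n2)cc1`, has not yet been measured in this assay. Against compound 2 the counted difference is bromo in place of fluoro on an aromatic carbon. Among the measured compounds shown here, no pair among the measured compounds differs in a single place, so there is no measured step to lean on. What the data do show is that compound 3, which also carries a 4-bromophenyl group, and compound 2, which carries a 4-fluorophenyl group, give values within the scatter of each other, although the two also differ elsewhere in the molecule.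

Compound 4 is therefore expected to sit close to compound 2, with a step from compound 2 to compound 4 of a 1.1-fold lower number from compound 2 to compound 4 (0.03 log units; within the scatter), that is, no change beyond the scatter in either direction. The estimate for compound 4 in this assay is 800 nM, with a range from 350 nM to 1800 nM.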

Compound 4, half-maximal inhibitory concentration: 961 nM
Estimate against measurement, compound 4: 1.2-fold (0.08 log units) below, and the stated range covers the measured number.
By their numbers in this assay, from the lowest: compounds 1, 2, 3 and 4 (each within the scatter of the next).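

In this assay, the change from 4-fluorophenyl to 4-bromophenyl gives a 1.1-fold higher number from compound 2 to compound 4 (0.05 log units; within the scatter), so this exchange of one halogen for another on an aromatic carbon, para to a large group, leaves the number level. Among the compounds shown here, this is the first comparison in the set that differs in one place only: the earlier hint about fluoro and bromo came from compounds that also differed elsewhere in the molecule, whereas here everything else is held the same, and the exchange still produces no change beyond the scatter. No measurement is available that bears on why the number stays level at this position.

For the compounds shown here, what this single pair shows holds for fluoro and bromo with the rest of compound 2 in place, and it remains open whether the same exchange would read the same way on another compound in the set, since compound 1 and compound 3 offer no pair of this kind. Going by these compounds, it also remains open whether a group of a different kind at this position, such as an amine, a carboxylic acid, a nitrile or a longer chain, would move the number beyond the scatter in either direction.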